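The source may report more compounds than this note shows. Statements on the series, on what has been measured and on what is new or still open speak of the compounds shown alone.

In an ADME assay on microsomes from liver (Homo sapiens) for metabolic stability, read by LC-MS, using NADPH, with a stated time of 30 min, tested at 1 uM (a higher number here means faster removal of the compound, a lower number slower removal), compound 1 `Cc1cc2c(cn1)Oc1ccc(NC(=O)c3ccc(Cl)cn3)cc1[C@@]21COC(N)=N1` gives 16 mL.min-1.g-1. Compound 2 `COc1cc2c(cn1)Oc1ccc(NC(=O)c3ccc(Cl)cn3)cc1[C@@]21COC(N)=N1` reaches only a limit of the assay, < 14 mL.min-1.g-1. Compound 3 `NC1=N[C@@]2(CO1)c1cc(-c3cncc(C#CC4CC4)c3)ccc1Oc1cnc(C3=CCOCC3)cc12` gives 80 mL.min-1.g-1, the highest number shown and beyond the scatter from compound 1. Compound 4 `CC1(C#Cc2cncc(-c3ccc4c(c3)[C@@]3(COC(N)=N3)c3cc(C5=CCOCC5)ncc3O4)c2)COC1` has yet to be measured. It differs from compound 3 by 3-methyloxetan-3-yl in place of cyclopropyl on a triple-bonded carbon, with 3-methyloxetan-3-yl in place of cyclopropyl on a triple-bonded carbon. For the measured compounds named here, the only measured step, an at least 1.1-fold lower number from compound 1 to compound 2 (0.05 log units; that floor lies within the scatter), is methoxy in place of methyl on an aromatic carbon. That is another change and gives no direct size for this one. The estimated step is a 1.6-fold lower number from compound 3 to compound 4 (0.20 log units; within the scatter), a modest fall in this assay that is not expected to clear the scatter. Compound 4 is expected at 50 mL.min-1.g-1, within 22 mL.min-1.g-1 to 95 mL.min-1.g-1.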

Compound 4, intrinsic clearance in microsomes: 420 mL.min-1.g-1
For compound 4 the middle estimate is 8.4-fold (0.92 log units) below the measured one, outside the stated range (above it).
By their numbers in this assay, from the lowest: compound 1; then compound 3; then compound 4. At a limit, below all of these: compound 2.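

In this assay the group on the triple-bonded carbon proves to matter: 3-methyloxetan-3-yl in place of cyclopropyl gives a 5.3-fold higher number from compound 3 to compound 4 (0.72 log units; beyond the scatter), and removal rises rather than falls. This is the only step shown at this place, and unlike the earlier step at another place, it lies clearly beyond the scatter. Nothing shown gives a cause for this rise. Going by these compounds, it remains open whether the ring oxygen or the methyl carries the rise, and how an amine or a tert-butyl group would behave on this carbon in this assay.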